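A few compounds are considered here, and "the series" means these few. Any claim that something is new, unique, unknown or untested is made for them only; others in the source may bear on it.

Measured compounds:
- compound 1, `COc1cc(NC(C)CCCNC(=O)NNC(=O)Nc2cccc(F)c2)c2ncccc2c1`. In a functional assay on MOLT-4 cells (Homo sapiens) for inhibition, read by MTT assay, with a stated time of 72 h (on this read-out lower numbers stand for stronger inhibition and higher numbers for weaker inhibition), compound 1 returns >= 250000 nM, which is a limit of the assay rather than a number.
- compound 2, `COc1cc(NC(C)CCCNC(=O)NNC(=O)Nc2ccc(Br)cc2)c2ncccc2c1`. In this assay compound 2 gives 209000 nM.
- compound 3, `COc1cc(NC(C)CCCNC(=O)NNC(=O)Nc2ccc(O)cc2)c2ncccc2c1`. In this assay compound 3 gives 104000 nM.

Compound 2 stands highest of the two numbers; its nearest neighbour is compound 3, with a 2.0-fold lower number from compound 2 to compound 3 (0.30 log units; within the scatter), so no order between the two is claimed. Compound 1 sits at the limit (the limit of >= 250000 nM in this assay, at which 1 of the 3 values shown sits), and the step of an at least 1.1-fold lower number from compound 1 to compound 2 (0.07 log units; that floor lies within the scatter) therefore carries a floor only.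

Compound 4, `COc1cc(NC(C)CCCNC(=O)NNC(=O)Nc2ccc(F)cc2)c2ncccc2c1`, differs from compound 2 in one place: fluoro in place of bromo on an aromatic carbon. Among the measured compounds shown here, no measured step exchanges these two groups at the same position. For the measured compounds named here, the steps that touch the same position are a 2.0-fold lower number from compound 2 to compound 3 (0.30 log units; within the scatter), within the scatter, and an at least 2.4-fold lower number from compound 1 to compound 3 (0.38 log units; beyond the scatter), beyond it, while the only fluoro-bearing compound so far, compound 1, is known only as a limit. The change from bromo to fluoro is small in what it counts and the neighbouring steps are small, so in this assay compound 4 is expected to stay within the scatter of compound 2, if anything drifting upward toward the limit, with a 1.1-fold higher number from compound 2 to compound 4 (0.04 log units; within the scatter) as the estimated step. The estimate for compound 4 is 230000 nM, expected between 120000 nM and 500000 nM.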

Compound 4, half-maximal inhibitory concentration: >= 250000 nM
Compound 4 gave a limit, no number; the forecaster's own chance of this, stated with the estimate: 40%; at least 1.0-fold (0.03 log units) between middle value and limit.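

In this assay compound 4 returns >= 250000 nM, which is a limit of the assay and not a number. Fluoro in place of bromo gives only a floor, an at least 1.1-fold higher number from compound 2 to compound 4 (0.07 log units; that floor lies within the scatter), so no order is claimed for that pair, while fluoro in place of hydroxy on the same aromatic carbon gives an at least 2.4-fold higher number from compound 3 to compound 4 (0.38 log units; beyond the scatter), the first step in the series that separates two groups at this position beyond the scatter and the first reading of a fluoro group there. The step between the 3-fluorophenyl and 4-fluorophenyl compounds cannot be read, so nothing can be said about where the fluoro group sits, and the series now presses against the top of the measurable range: the limit of >= 250000 nM in this assay, at which 2 of the 4 values shown sit.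

Among the compounds shown here, compound 3, at 104000 nM, remains the only compound here with a step beyond the scatter to a fluoro compound, and its own difference from compound 2 stays within the scatter, so one hydroxy compound does not establish a trend. As far as these compounds go, whether an amine or a carboxylic acid on the same aromatic carbon, or a longer chain in the linker, would bring the numbers well below this range remains open.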